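The compounds below may be only part of what the source reports. "The series", "measured", "known", "first", "only" and "open" are said of these compounds alone.

Measured in a functional assay on NCI-H460 cells (Homo sapiens) for antiproliferative activity, read by CCK-8 assay, with a stated time of 72 h, tested at 2 uM; on this read-out higher numbers stand for a stronger effect at the one concentration tested and lower numbers for a weaker effect:
compound 1 `CC(C)n1cnc2c(Nc3ccccc3)nc(NCOCc3ccc(C(=O)Nc4ccccc4N)cc3)nc21` gives 15%;
compound 2 `Nc1ccccc1NC(=O)/C=C/c1ccc(COCNc2nc(Nc3cccc(Cl)c3)c3ncn(C4CCCC4)c3n2)cc1` gives 37.1%;
compound 3 `CC(C)n1cnc2c(Nc3ccccc3)nc(NCOCc3ccc(/C=C/C(=O)Nc4ccccc4N)cc3)nc21` gives 41%.

Compound 3 has the highest of the three numbers. Compound 2 lies closest, within the usual scatter, so no order between the two can be claimed; compound 1 lies furthest, and the one-place step a number 26 percentage points higher from compound 1 to compound 3 (beyond the scatter) is beyond the scatter.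

Compound 4 `Nc1ccccc1NC(=O)/C=C/c1ccc(COCNc2nc(Nc3ccccc3)c3ncn(C4CCCC4)c3n2)cc1` differs from compound 3 in one place: cyclopentyl in place of isopropyl on an aromatic nitrogen. Among the compounds with values here, no measured step isolates this change. Compound 2 does carry cyclopentyl, but it differs from compound 3 in a second place as well; its value and that of compound 3 are within the scatter of each other. Compound 4 is therefore expected to give about 40% (range 25% to 55%), a step of a number 1 percentage points lower from compound 3 to compound 4 (within the scatter) expected to stay within the scatter.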

Compound 4, a percentage reported as inhibition, at one concentration (the size of the read-out at that concentration, not a potency): 52%
Compound 4: middle estimate off by 12 percentage points, on the low side; the range from low to high includes it.
By their numbers in this assay, from the lowest: compound 1; then compounds 2 and 3 (each within the scatter of the next); then compound 4.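

In this assay, within the data shown here, the substituent on the aromatic nitrogen matters: cyclopentyl in place of isopropyl gives a number 11 percentage points higher from compound 3 to compound 4 (beyond the scatter) and so isolates this change for the first time. With cyclopentyl held, hydrogen in place of chloro on an aromatic carbon gives a number 14.9 percentage points higher from compound 2 to compound 4 (beyond the scatter) and shows that this second place also counts. Nothing available explains either step.

The compounds shown leave open whether a cyclohexyl or cyclopropyl group on that nitrogen would follow cyclopentyl or isopropyl. They also leave open how a fluoro or methoxy group would compare with hydrogen and chloro on that aromatic carbon.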